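The compounds below may be only part of what the source reports. "The series", "measured", "known", "first", "only" and "open" are said of these compounds alone.

Measured compounds:
compound 1, `CSc1nncc2c(C)nc(C(C)C)n12`: > 48000 nM
compound 2, `Cc1nc(C)n2c(S)nncc12`: > 48000 nM

Compound 2, `Cc1nc(C)n2c(S)nncc12`, stands at the ceiling of what a functional assay for inhibition, with Homo sapiens as the target (on this read-out higher numbers stand for weaker inhibition and lower numbers for stronger inhibition), reports: the value > 48000 nM for compound 2 is a limit of the assay and not a number. Compound 1, `CSc1nncc2c(C)nc(C(C)C)n12`, also returns only a limit in this assay, namely > 48000 nM. For the measured compounds named here, both values shown in this assay sit at the same point, (the limit of > 48000 nM in this assay, at which 2 of the 2 values shown sit), so no measured step is available and no direction of change is known from the data.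

The unmeasured compound 3, `CSc1nncc2c(C)nc(C)n12`, differs from compound 2 in one place: methyl in place of hydrogen on a sulfur. Compound 1 carries the same methylsulfanyl group and gives only a limit, so neither of the two values shown points toward measurable inhibition. The step from compound 2 to compound 3 is expected to be a step that the limit leaves unreadable from compound 2 to compound 3, nothing beyond the scatter, with a limit the most probable outcome. The estimate for compound 3 in this assay is 70000 nM, within a range from 20000 nM to 250000 nM.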

Compound 3, half-maximal inhibitory concentration: > 48000 nM
Compound 3: no number, only a limit; the forecaster's own chance of this, stated with the estimate: 85%; the middle value lies beyond the limit too.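

In this assay compound 3 gives > 48000 nM as a limit and not a number. For the compounds shown here, no step from compound 1 or compound 2 to compound 3 can be read, because all three compounds sit at one point: the limit of > 48000 nM in this assay, at which 3 of the 3 values shown sit. The compounds shown leave open whether this assay can return a number for any change on the shared core.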